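The source may report more compounds than this note shows. Statements on the series, on what has been measured and on what is new or still open speak of the compounds shown alone.

Compound 1 `O=C(Nc1cccc(-c2nc(-c3ccc(NC(=O)c4cccnc4)cc3Cl)no2)c1)c1ccccc1` gives 12800 nM in a functional assay on MDA-MB-231 cells (Homo sapiens) for antiproliferative activity, read by MTT assay, with a stated time of 72 h; a lower number here means a stronger inhibitor, a higher number a weaker inhibitor. Compound 2 `O=C(Nc1ccc(-c2noc(-c3cccc(NS(=O)(=O)c4ccc(C(F)(F)F)cc4)c3)n2)c(Cl)c1)c1cccnc1` gives only a limit of this assay, namely > 10000 nM.

From the compounds shown here alone, compound 2 therefore stands at the edge of what this assay reports (the limit of > 10000 nM in this assay, at which 1 of the 2 values shown sits), and its true value is unknown. Compound 3 `CNC(=O)Nc1ccc(S(=O)(=O)Nc2cccc(-c3nc(-c4ccc(NC(=O)c5cccnc5)cc4Cl)no3)c2)cc1` differs from compound 2 in one place: (methylcarbamoyl)amino in place of trifluoromethyl on an aromatic carbon. Within the data shown here, no step between measured compounds is available to size this change, so the expectation rests on compound 2 alone. Compound 3 is expected to remain weak, with a step of an at least 1.1-fold lower number from compound 2 to compound 3 (0.04 log units; that floor lies within the scatter) that stays within the scatter, though a modest gain cannot be excluded. The estimate for compound 3 in this assay is 9000 nM, between 2500 nM and 30000 nM.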

Compound 3, half-maximal inhibitory concentration: 1300 nM
Estimate against measurement, compound 3: 6.9-fold (0.84 log units) above, outside the stated range (below it).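

In this assay, placing (methylcarbamoyl)amino instead of trifluoromethyl on this aromatic carbon, para to a large group, gives an at least 7.6-fold lower number from compound 2 to compound 3 (0.88 log units; beyond the scatter) in this series, so the group at this position clearly affects the antiproliferative read-out. From the compounds shown here alone, the true size of this step remains unknown, because the value for compound 2 is a limit and not a number: the limit of > 10000 nM in this assay, at which 1 of the 3 values shown sits.

Going by these compounds, it remains open which part of the (methylcarbamoyl)amino group carries the gain, and whether a simple amine or a carboxylic acid at this place would match it.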